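The source may report more compounds than this note shows. Statements on the series, on what has been measured and on what is new or still open speak of the compounds shown alone.

Compounds measured in a functional assay on SMMC-7721 cells (Homo sapiens) for cytotoxicity, read by MTT assay, with a stated time of 72 h; on this read-out higher numbers stand for weaker inhibition and lower numbers for stronger inhibition:
compound 1 `O=C1C(=Cc2ccc(O)cc2)C(=O)N(c2ccc(Cl)cc2)N1c1ccc(Cl)cc1`: 20600 nM
compound 2 `COc1cc(C=C2C(=O)N(c3ccc(Cl)cc3)N(c3ccc(Cl)cc3)C2=O)ccc1O`: 64900 nM
compound 3 `COc1ccc(C=C2C(=O)N(c3ccc(Cl)cc3)N(c3ccc(Cl)cc3)C2=O)cc1OC`: > 128000 nM (a limit, not a number)

Compound 3 stands only at a limit, > 128000 nM, and the other two compounds carry real numbers. This makes any step starting from compound 3 a comparison with a limit.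

Next comes compound 4 `O=C1C(=Cc2ccco2)C(=O)N(c2ccc(Cl)cc2)N1c1ccc(Cl)cc1`, with furan-2-yl in place of 3,4-dimethoxyphenyl on a double-bonded chain carbon bound to a double-bonded ring carbon.

All three measured steps change this same substituent. They are a 3.2-fold higher number from compound 1 to compound 2 (0.50 log units; beyond the scatter), then an at least 6.2-fold higher number from compound 1 to compound 3 (0.79 log units; beyond the scatter), and finally an at least 1.9-fold higher number from compound 2 to compound 3 (0.29 log units; that floor lies within the scatter). Across these three compounds the numbers rise from the 4-hydroxyphenyl compound to the 3,4-dimethoxyphenyl compound, and no compound here goes against that order. None of them carries furan-2-yl, so the evidence for compound 4 is indirect.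

Compound 2, at 64900 nM, serves as the working anchor, since its number is higher than that of compound 1 at 20600 nM. A modest move toward stronger inhibition in this assay is expected, an at least 2.1-fold lower number from compound 3 to compound 4 (0.32 log units; beyond the scatter), and a result at the limit would not be surprising. For compound 4 the estimated value is 60000 nM, with an expected range from 22000 nM to 128000 nM.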

Compound 4, half-maximal inhibitory concentration: 19500 nM
For compound 4 the middle estimate is 3.1-fold (0.49 log units) above the measured one, and the stated range ends above it.
By their numbers in this assay, from the lowest: compounds 4 and 1 (each within the scatter of the next); then compound 2. At a limit, above all of these: compound 3.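

In this assay, this place on a double-bonded chain carbon bound to a double-bonded ring carbon tolerates a group that is not a substituted phenyl: replacing the hydroxyphenyl group with furan-2-yl gives a 1.1-fold lower number from compound 1 to compound 4 (0.02 log units; within the scatter), so the two groups cannot be told apart here. The same replacement gives a 3.3-fold lower number from compound 2 to compound 4 (0.52 log units; beyond the scatter), and against the dimethoxy group it gives an at least 6.5-fold lower number from compound 3 to compound 4 (0.81 log units; beyond the scatter), which shows that the order seen among the three phenyl compounds does not extend to every group at this place. Both 3,4-dimethoxyphenyl and furan-2-yl count 0 hydrogen-bond donors, so donor count alone does not separate them, and the step from compound 3 is only a floor, with compound 3 standing at a limit: the limit of > 128000 nM in this assay, at which 1 of the 4 values shown sits.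

Furan-2-yl differs from the phenyl groups in ring size, hetero atom and heavy-atom count all at once, so these compounds do not show which of these differences tracks the numbers. A thiophene ring at this place, or an amine on the phenyl ring, would separate these readings, and the compounds shown say nothing about changes elsewhere on the shared core.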